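A few compounds are considered here, and "the series" means these few. Any claim that something is new, unique, unknown or untested is made for them only; others in the source may bear on it.

Working notes on the series. In an ADME assay on microsomes from liver (Homo sapiens) for metabolic stability, read by LC-MS, using NADPH, with a stated time of 30 min, tested at 1 uM (on this read-out lower numbers stand for a less stable compound and higher numbers for a more stable compound), compound 1 (`C=CC(=O)Nc1cc(Nc2ncc(I)c(Nc3ccccc3S(=O)(=O)N(C)C)n2)c(OC)cc1N(C)CCN(C)C`) stands at 13% and compound 2 (`C=CC(=O)Nc1cc(Nc2ncc(F)c(Nc3ccccc3S(=O)(=O)N(C)C)n2)c(OC)cc1N(C)CCN(C)C`) at 9% while compound 3 (`C=CC(=O)Nc1cc(Nc2ncc(Cl)c(Nc3ccccc3S(=O)(=O)C(C)C)n2)c(OC)cc1N(C)CCN(C)C`) stands at 16% and so lies within the scatter of both. Compound 4 (`C=CC(=O)Nc1cc(Nc2ncc(Cl)c(Nc3ccccc3S(=O)(=O)N(C)C)n2)c(OC)cc1N(C)CCN(C)C`) departs from compound 3 in one place. The change is dimethylamino in place of isopropyl on a sulfonyl sulfur. Within the data shown here, no measured pair isolates this change. Among the measured compounds shown here, the only measured single-place step is a number 4 percentage points lower from compound 1 to compound 2 (within the scatter) (fluoro in place of iodo on an aromatic carbon) and it stays within the scatter, so it bears on the halogen only. Compound 4 shares the dimethylamino group on the sulfonyl sulfur with compound 1 (13%) and compound 2 (9%) and differs from them only in the halogen, so a value close to theirs is expected. The step expected is a number 5 percentage points lower from compound 3 to compound 4 (within the scatter) and is not expected to exceed the scatter. The estimate for compound 4 is 11% with 5% to 20% as its expected range.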

Compound 4, percent of the compound remaining: 11%
Compound 4: the middle estimate sits on the measured number at the digits printed; measured number inside the range.
By their numbers in this assay, from the lowest: compounds 2, 4, 1 and 3 (each within the scatter of the next).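

In this assay, the change on the sulfonyl sulfur now has a measured pair of its own: dimethylamino in place of isopropyl gives a number 5 percentage points lower from compound 3 to compound 4 (within the scatter) and so does not separate the two groups. With dimethylamino held, the halogen on the aromatic carbon now has three measured members, with chloro in place of fluoro giving a number 2 percentage points higher from compound 2 to compound 4 (within the scatter) and chloro in place of iodo giving a number 2 percentage points lower from compound 1 to compound 4 (within the scatter) and neither step separating the halogens. No measurement available on this series accounts for any of these steps.

Still open, from the compounds shown here alone, is whether a different group on the sulfonyl sulfur, such as morpholine or cyclopropyl, would give a step beyond the scatter. Also open, going by these compounds, is whether a piperazine elsewhere on the shared core would move the percent remaining away from these four compounds.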